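Shortening the chain on the ring carbon of compound 1

A few compounds are considered here, and "the series" means these few. Any claim that something is new, unique, unknown or untested is made for them only; others in the source may bear on it.

Compound 1 `CC[C@@H]1C(=O)N(C)c2cnc(Nc3ccc(C(=O)NC4CCN(C)CC4)cc3OC)nc2N1C1CCCCC1` is the reference of this pair. In an assay on isolated protein for inhibition of serine/threonine-protein kinase PLK1 (Homo sapiens), read by Z'-LYTE (on this read-out lower numbers stand for stronger inhibition and higher numbers for weaker inhibition), compound 1 gives 4 nM, the lowest of the two numbers in hand. Among the measured compounds shown here, its only measured neighbour is compound 2 `CC[C@@H]1C(=O)Nc2cnc(Nc3ccc(C(=O)NC4CCN(C)CC4)cc3OC)nc2N1C1CCCCC1`, which in this assay gives 37.2 nM; the step of a 9.3-fold higher number from compound 1 to compound 2 (0.97 log units; beyond the scatter) corresponds to hydrogen in place of methyl on an amide-type nitrogen in a ring.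

Compound 3 `COc1cc(C(=O)NC2CCN(C)CC2)ccc1Nc1ncc2c(n1)N(C1CCCCC1)[C@H](C)C(=O)N2C` is not yet measured. It differs from compound 1 by hydrogen in place of methyl on a saturated chain carbon bound to a saturated ring carbon; cut one bond further out, the change reads ethyl to methyl. For the measured compounds named here, no measured step touches this saturated chain carbon: the one step in hand sits on the ring nitrogen and says nothing about the chain. Removal of the methyl from the chain is taken here to be a small change, so no step beyond the scatter is expected in this assay, with a slight lean toward a higher number. The expected step is a 1.5-fold higher number from compound 1 to compound 3 (0.18 log units; within the scatter). For compound 3 in this assay the estimate is 6 nM, with a range from 2 nM to 20 nM.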

Compound 3, half-maximal inhibitory concentration: 8.6 nM
The estimate for compound 3 lay 1.4-fold (0.16 log units) below the measured number; low and high end bracket the measured number.
By their numbers in this assay, from the lowest: compound 1; then compound 3; then compound 2.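

In this assay the saturated chain carbon bound to a saturated ring carbon now has a reading of its own: ethyl to methyl gives a 2.2-fold higher number from compound 1 to compound 3 (0.33 log units; beyond the scatter) and so registers on this read-out, though the step is modest. Of the two single changes read from compound 1, the one on the chain is the smaller in size, the one on the amide-type nitrogen in a ring being a 9.3-fold higher number from compound 1 to compound 2 (0.97 log units; beyond the scatter) here. Nothing in hand bears on why ethyl gives the lower number.

With only ethyl and methyl on this carbon, two points say nothing about a trend with chain length, so the compounds shown leave open where a propyl chain, a branched isopropyl group or a cyclopropyl group would fall, and how a longer chain would compare with compound 1, which gives 4 nM. Also open, on these data alone, are an amine or a hydroxyl on the chain, and whether the chain change and the change on the amide-type nitrogen add up when both are made in one compound.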